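Swapping methyl for methoxy on the aromatic ring

The compounds below may be only part of what the source reports. "The series", "measured", "known", "first", "only" and "open" are said of these compounds alone.

Compound 1 `CCCn1ccnc1-c1cc(OC)c(OC)c(OC)c1` gives > 100000 nM
Compound 2 `COc1ccc(-n2ccnc2-c2cc(OC)c(OC)c(OC)c2)cc1[N+](=O)[O-]` gives 7500 nM
Compound 3 `COc1cc(-c2nccn2-c2ccc(C)cc2)cc(OC)c1OC` gives 4100 nM

In a functional assay on MDA-MB-231 cells (Homo sapiens) for antiproliferative activity, read by MTT assay, with a stated time of 72 h (a lower number here means a stronger inhibitor, a higher number a weaker inhibitor), compound 3 gives 4100 nM and compound 2 gives 7500 nM and these two values lie within the usual scatter of each other. Compound 1 reads > 100000 nM in this assay and this is a limit of the assay, not a number.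

The next compound, compound 4 `COc1ccc(-n2ccnc2-c2cc(OC)c(OC)c(OC)c2)cc1`, differs from compound 3 by one small change: methoxy in place of methyl on an aromatic carbon, para to a large group (methoxy in place of methyl on an aromatic carbon).

For the measured compounds named here, only one measured step bears on this directly. Putting 4-methylphenyl in place of propyl on an aromatic nitrogen gave an at least 24-fold lower number from compound 1 to compound 3 (1.38 log units; beyond the scatter), a large step. That step brought in the aromatic ring, and compound 4 keeps this ring, changing only a small group on it. Compound 2 also carries a methoxy on that ring, together with a nitro group, and its value of 7500 nM lies within the scatter of compound 3. Going by the values given here, no large step is therefore expected here.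

The expected change is a 1.2-fold lower number from compound 3 to compound 4 (0.07 log units; within the scatter) in this assay and so stays within the scatter. Compound 4 is estimated at 3500 nM as a middle value, with an expected range from 1200 nM to 10000 nM around it.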

Compound 4, half-maximal inhibitory concentration: 2700 nM
Compound 4: middle estimate off by 1.3-fold (0.11 log units), on the high side; the measured number falls inside the stated range.
By their numbers in this assay, from the lowest: compounds 4, 3 and 2 (each within the scatter of the next, the first and the last beyond it). At a limit, above all of these: compound 1.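

In this assay, methoxy in place of methyl on an aromatic carbon, para to a large group, gave a 1.5-fold lower number from compound 3 to compound 4 (0.18 log units; within the scatter), so at this position 4-methylphenyl and 4-methoxyphenyl cannot be told apart, whereas hydrogen in place of nitro on the same ring gave a 2.8-fold lower number from compound 2 to compound 4 (0.44 log units; beyond the scatter), a modest step that lies beyond the scatter. The earlier compounds shown here showed a large gain from an aromatic ring on the nitrogen only with 4-methylphenyl, and 4-methoxyphenyl in place of propyl now repeats it, giving an at least 37-fold lower number from compound 1 to compound 4 (1.56 log units; beyond the scatter), so the gain does not depend on the methyl group. The size of that step is only a bound, and compound 1 gives a limit of the assay and not a number: the limit of > 100000 nM in this assay, at which 1 of the 4 values shown sits.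

The compounds shown leave open whether this tolerance at the ring carbon extends beyond methyl and methoxy to a group such as an amine, a hydroxyl or a carboxylic acid. They also leave open whether a longer chain such as butoxy would be accepted there, and whether a benzyl group on the nitrogen could stand in for the directly attached aromatic ring.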